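The source may hold more compounds than are shown below. What is called first, only, known or untested is meant among the compounds shown, and "the series" means these compounds.

Measured compounds in a functional assay (T-cell) for inhibition, with Cavia porcellus as the target, read by thymidine incorporation; on this read-out higher numbers stand for weaker inhibition and lower numbers for stronger inhibition:
- compound 1 `OCC1OC(SC/C=C/c2ccccc2)C(O)C(O)C1O`: 871000 nM
- compound 2 `CC1OC(OCC2OC(SCCCc3ccccc3)C(O)C(O)C2O)C(O)C(O)C1O`: 340000 nM

Of these two, compound 1 shows the higher number in this assay, and compound 2 the lower one, a gap that lies beyond the usual scatter. Compound 3 `COCC1OC(SC/C=C/c2ccccc2)C(O)C(O)C1O` differs from compound 1 by methyl in place of hydrogen on an oxygen on a saturated carbon. Nothing measured shows what this change alone does, so the expected step in this assay is small, in no settled direction, and is estimated to stay within the scatter: a 1.2-fold lower number from compound 1 to compound 3 (0.06 log units; within the scatter). On that basis compound 3 is expected to give about 750000 nM, with a range from 250000 nM to 2200000 nM.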

Compound 3, half-maximal inhibitory concentration: 41000 nM
Beside the measured number, compound 3's estimate is 18-fold (1.26 log units) above it; the measured number lies below the stated range.
By their numbers in this assay, from the lowest: compound 3; then compound 2; then compound 1.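

In this assay, the change from hydroxymethyl to methoxymethyl gives a 21-fold lower number from compound 1 to compound 3 (1.33 log units; beyond the scatter), a large step towards stronger inhibition. This oxygen on a saturated carbon is therefore a position where the read-out responds strongly to substitution, even though the entering methyl adds only 1 heavy atom. Nothing available here explains the step. The compounds shown leave open whether an ethyl group on this oxygen would go further or lose the gain, and whether an amine in place of the hydroxy would keep it.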